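Compound 3 to compound 4: a change on the sulfonyl sulfur

The source may hold more compounds than are shown below. What is called first, only, known or untested is meant among the compounds shown, and "the series" means these compounds.

Measured in a functional assay on A2780 cells (Homo sapiens) for antiproliferative activity, read by MTT assay, with a stated time of 48 h; on this read-out lower numbers stand for stronger inhibition and higher numbers for weaker inhibition:
Compound 1 `CCOc1ccc(-c2nc(N(Cc3ccccc3)Cc3ccccc3)sc2-c2cc(OC)c(OC)c(OC)c2)cc1`: > 5000 nM
Compound 2 `CCOc1ccc(-c2sc(N)nc2-c2cc(OC)c(OC)c(OC)c2)cc1`: 8.6 nM
Compound 3 `CCOc1ccc(-c2nc(NS(=O)(=O)c3ccc([N+](=O)[O-])cc3OC)sc2-c2cc(OC)c(OC)c(OC)c2)cc1`: > 5000 nM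

Only compound 2 gives a number here, 8.6 nM. Compound 1 gives a limit of the assay, > 5000 nM. Compound 3 also gives only a limit, > 5000 nM. It stands at the limit of > 5000 nM in this assay, at which 2 of the 3 values shown sit, so its true potency is not known.

The next compound is compound 4 `CCOc1ccc(-c2nc(NS(=O)(=O)c3ccc(C)c(C)c3)sc2-c2cc(OC)c(OC)c(OC)c2)cc1`. It has 3,4-dimethylphenyl in place of 2-methoxy-4-nitrophenyl on a sulfonyl sulfur whose other neighbour is the sulfonamide nitrogen: 3,4-dimethylphenyl in place of 2-methoxy-4-nitrophenyl on a sulfonyl sulfur. The rest of the structure is unchanged.

Going by the values given here, no measured pair in this set differs at this one place, so the size of the step can only be judged from compound 3 itself. The expectation starts from compound 3, with its limit of > 5000 nM. The expected step of a number no higher from compound 3 to compound 4 (the limit leaves the size open) in this assay is small, and if there is any shift it should be towards slightly stronger inhibition. Another reading at the limit is quite likely. Compound 4 is estimated at 5000 nM, with an expected range of 1500 nM to 15000 nM.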

Compound 4, half-maximal inhibitory concentration: > 5000 nM
Compound 4 ended at the assay's limit; the forecaster's own chance of this, stated with the estimate: 60%; the middle value lies on the limit itself.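

In this assay compound 4 gives > 5000 nM, which is a limit of the assay. Going by these compounds alone, compound 3 gives > 5000 nM, also a limit, so no step from compound 3 to compound 4 can be read. Both stand at the same limit: the limit of > 5000 nM in this assay, at which 3 of the 4 values shown sit.

The compounds shown leave open whether 3,4-dimethylphenyl or 2-methoxy-4-nitrophenyl on the sulfonyl sulfur gives the stronger inhibition.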